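Three halogen and methoxy amides, and a fourth

The source may hold more compounds than are shown below. What is called first, only, known or untested is meant among the compounds shown, and "the series" means these compounds.

Measured so far in a functional assay on A-375 cells (Homo sapiens) for antiproliferative activity, read by MTT assay, with a stated time of 48 h; a higher number here means a weaker inhibitor, a lower number a stronger inhibitor

- compound 1 (`O=C(Nc1cc(-c2ccccc2)[nH]n1)c1cccnc1F`) gives 4880 nM
- compound 2 (`COc1ncccc1C(=O)Nc1cc(-c2ccccc2)[nH]n1`) gives 9940 nM
- compound 3 (`O=C(Nc1cc(-c2ccccc2)[nH]n1)c1cncc(Br)c1`) gives 8120 nM

Compound 3, at 8120 nM, cannot be separated from either compound 1 or compound 2 on these numbers. The change to compound 4 (`O=C(Nc1cc(-c2ccccc2)[nH]n1)c1ccc(Cl)nc1`) is 6-chloropyridin-3-yl in place of 5-bromopyridin-3-yl on a carbonyl carbon. One measured exchange touches this same place, a 1.7-fold higher number from compound 1 to compound 3 (0.22 log units; within the scatter), and it stays small. The other, a 2.0-fold higher number from compound 1 to compound 2 (0.31 log units; beyond the scatter), puts methoxy in place of fluoro on an aromatic carbon and is modest. No step beyond the scatter is therefore expected in this assay, and the estimated change is a 1.2-fold lower number from compound 3 to compound 4 (0.06 log units; within the scatter). Compound 4 is expected at 7000 nM, with an estimated range from 3500 nM to 14000 nM.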

Compound 4, half-maximal inhibitory concentration: 7850 nM
For compound 4 the middle estimate is 1.1-fold (0.05 log units) below the measured one; the range from low to high includes it.
By their numbers in this assay, from the lowest: compounds 1, 4, 3 and 2 (each within the scatter of the next, the first and the last beyond it).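

In this assay, 6-chloropyridin-3-yl on the carbonyl carbon cannot be told apart from 5-bromopyridin-3-yl, with a 1.0-fold lower number from compound 3 to compound 4 (0.01 log units; within the scatter), or from 2-fluoropyridin-3-yl, with a 1.6-fold higher number from compound 1 to compound 4 (0.21 log units; within the scatter). Among compounds 1, 3 and 4, then, changing the halogen and where it sits on the pyridine gives no step beyond the scatter. Nothing available explains this flat result. Going by these compounds, it remains open whether an amine or a carboxylic acid on the pyridine would produce a clear step at this position.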